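Fluoro on the Core of Compound 2: Expected Exposure

The source may report more compounds than this note shows. Statements on the series, on what has been measured and on what is new or still open speak of the compounds shown alone.

In an ADME assay on the whole organism (Macaca fascicularis) for pharmacokinetics, read by LC-MS, using cassette dosing, at a dose of 1 mg/kg by the oral route (on this read-out higher numbers stand for higher exposure at the dose given and lower numbers for lower exposure), three compounds have been measured. For the measured compounds named here, compound 1 `CCCCN(c1nc2ccccc2o1)[C@H](C)c1ccc(-c2ccccc2-c2nnn[nH]2)cc1` gives 29.2 nM, and compound 3 `CCCCN(c1nc2c(C(=O)N(C)C)cccc2o1)[C@H](C)c1ccc(-c2ccccc2-c2nnn[nH]2)cc1` gives 54 nM; the only single-point step among them is a 1.8-fold higher number from compound 1 to compound 3 (0.27 log units; within the scatter). Compound 2 `C[C@H](c1ccc(-c2ccccc2-c2nc(=O)o[nH]2)cc1)N(CC1CC1)c1nc2c(C(=O)O)cccc2o1` stands apart with 7710 nM, the highest of the three numbers, beyond the scatter from both compound 3 and compound 1.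

Compound 4 `C[C@H](c1ccc(-c2cc(F)ccc2-c2nc(=O)o[nH]2)cc1)N(CC1CC1)c1nc2c(C(=O)O)cccc2o1` differs from compound 2 by fluoro in place of hydrogen on an aromatic carbon. Going by the values given here, no measured step concerns a fluoro; the one measured step, a 1.8-fold higher number from compound 1 to compound 3 (0.27 log units; within the scatter), adds a different group and stays within the scatter, so it gives no reason to expect a sizeable shift. The change is a single heavy atom with no donors or acceptors, and the acid on the shared core of compound 2 is kept. Compound 4 is therefore expected to stay close to compound 2, with a 1.2-fold lower number from compound 2 to compound 4 (0.07 log units; within the scatter) as the expected step. The estimate for compound 4 in this assay is 6500 nM, within a range of 2200 nM to 19000 nM.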

Compound 4, maximal plasma concentration: 2900 nM
Estimate against measurement, compound 4: 2.2-fold (0.35 log units) above; the measured number falls inside the stated range.
By their numbers in this assay, from the lowest: compounds 1 and 3 (each within the scatter of the next); then compound 4; then compound 2.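

In this assay, the step of a 2.7-fold lower number from compound 2 to compound 4 (0.42 log units; beyond the scatter) shows that this place on the six-membered aromatic ring of carbon only, meta to a large group and para to a group of 6 heavy atoms, can register a change: fluoro, with its 1 heavy atom, moves the number beyond the scatter, though only modestly. For the compounds shown here, the earlier step, a 1.8-fold higher number from compound 1 to compound 3 (0.27 log units; within the scatter), involved dimethylcarbamoyl at a different place on a different core and stayed within the scatter, so this is the first single-place change here that can be read as a real drop. Nothing at hand accounts for that drop.

The compounds shown leave open whether chloro, methyl or methoxy at this same place would lower the number as well. They also leave open whether fluoro here would give a like step on the core of compound 3.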